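The source may hold more compounds than are shown below. What is called first, only, known or untested is meant among the compounds shown, and "the series" means these compounds.

In a functional assay on the whole organism (brain) with Mus musculus as the target (a lower number here means that less compound is needed, a higher number that more compound is needed for the effect), compounds that share one core differ only in the group on an aromatic carbon. Compound 1 `COC(=O)c1ccc(OCCc2c[nH]cn2)cc1`, with methoxycarbonyl, reads > 3 mg/kg, which is a limit of the assay and not a number. Compound 2 `Clc1ccc(OCCc2c[nH]cn2)cc1`, with chloro, gives 0.78 mg/kg. Compound 3 `FC(F)(F)c1ccc(OCCc2c[nH]cn2)cc1`, with trifluoromethyl, reads > 10 mg/kg, so it too stands at a limit and has no exact value.

Compound 4 `CCCc1ccc(OCCc2c[nH]cn2)cc1` has propyl in place of trifluoromethyl on an aromatic carbon. Among the compounds with values here, no measured step involves propyl, so the evidence is indirect. Chloro in place of methoxycarbonyl gave an at least 3.8-fold lower number from compound 1 to compound 2 (0.58 log units; beyond the scatter), a modest step at the least. Trifluoromethyl in place of chloro gave an at least 12-fold higher number from compound 2 to compound 3 (1.10 log units; beyond the scatter), a large one, and this is the closest guide. A clearly lower number is therefore expected, though its size is uncertain. The expected step is an at least 3.3-fold lower number from compound 3 to compound 4 (0.52 log units; beyond the scatter). For compound 4 the estimated value is 3 mg/kg, with an expected range from 0.7 mg/kg to 12 mg/kg.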

Compound 4, dose for half-maximal effect: 1.6 mg/kg
For compound 4 the middle estimate is 1.9-fold (0.27 log units) above the measured one, and the stated range covers the measured number.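

In this assay, within the data shown here, propyl shows that a group made only of carbon can sit at this position and still give an exact dose, with an at least 6.2-fold lower number from compound 3 to compound 4 (0.79 log units; beyond the scatter), so chloro is not the only group here to do so. Propyl does not match chloro, however: a 2.1-fold higher number from compound 2 to compound 4 (0.31 log units; beyond the scatter) is the one new step between two exact values, and it is modest. Methoxycarbonyl gives the least firm comparison, an at least 1.8-fold lower number from compound 1 to compound 4 (0.27 log units; that floor lies within the scatter), and that reading rests on a limit of the assay for compound 1: the limit of > 3 mg/kg in this assay, at which 1 of the 4 values shown sits.

The compounds shown leave open whether a longer chain such as butyl, or an amine, at this position would give a lower number than chloro does. They also leave open how far the true doses of compound 1 and compound 3 lie beyond their limits.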